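Replacing the phenyl group of compound 1

The source may hold more compounds than are shown below. What is called first, only, known or untested is meant among the compounds shown, and "the series" means these compounds.

Measured so far in an ADME assay on microsomes from liver (Rattus norvegicus) for metabolic stability, read by LC-MS, with a stated time of 1 h, at 37 degrees C, tested at 4 uM (a higher number here means that more of the compound is left, a lower number that less of the compound is left), as the only read-out:
compound 1 `O=C1c2ccc(OCc3cccc(-c4ccccc4)c3)cc2CN1C1CCCC1` at 38% remaining
compound 2 `CN(C)C(=O)c1cc(-c2cccc(COc3ccc4c(=O)n(C5CCCC5)sc4c3)c2)ccc1Cl` at 92% remaining

Compound 1 holds the lower of the two values, and its gap to compound 2 lies beyond the usual scatter. Compound 3 `O=C(O)c1ccc(Cl)c(-c2cccc(COc3ccc4c(c3)CN(C3CCCC3)C4=O)c2)c1` has not yet been measured. It differs from compound 1 by 5-carboxy-2-chlorophenyl in place of phenyl on an aromatic carbon and this change sits meta to a large group. Within the data shown here, no measured step between compounds is available, so any expectation is loose. A clear rise is expected in this assay. Among the measured compounds shown here, the only guide is compound 2 at 92% as the higher value seen so far. The estimated change is a number 40 percentage points higher from compound 1 to compound 3 (beyond the scatter) on this thin basis. For compound 3 the expected value is 78% (estimated range 55% to 96%).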

Compound 3, percent of the compound remaining: 15%
The estimate for compound 3 lay 63 percentage points above the measured number; measured number below the stated range.
By their numbers in this assay, from the lowest: compound 3; then compound 1; then compound 2.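

In this assay, 5-carboxy-2-chlorophenyl in place of phenyl on an aromatic carbon, meta to a large group, gives a number 23 percentage points lower from compound 1 to compound 3 (beyond the scatter). The position is therefore not silent in this read-out: on the core of compound 1, this larger aryl group, which brings one hydrogen-bond donor and one hydrogen-bond acceptor, leaves less of the compound than plain phenyl does. Nothing on hand accounts for this step.

The carboxylic acid and the chlorine enter together, so their separate shares in the step remain unresolved. Also open, going by these compounds, is how this read-out would respond on the same core to a methyl ester, a primary amide or a tetrazole in place of the carboxylic acid, or to a fluorine in place of the chlorine.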